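The compounds below may be only part of what the source reports. "The series", "measured", "known", "first", "only" and "open" are said of these compounds alone.

The series comprises compound 1 `CCCCCCCCNCCO`, compound 2 `CCCCCCCCCCCCNCCCN` and compound 3 `CCCCCCCCCCC(O)CNCCO`. In a physicochemical assay for lipophilicity (on this read-out lower numbers stand for lower lipophilicity and higher numbers for higher lipophilicity), compound 1 gives 2.55, the lowest of the three; compound 3 gives 3.62, beyond the scatter above it, and compound 2 gives 5.06, furthest above. Among the measured compounds shown here, no two measured compounds differ in a single place, so no measured step is available. Compound 4 `CCCCCCCCCCNCCO` differs from compound 1 by ethyl in place of hydrogen on a saturated chain carbon, eight bonds along the chain from an amine nitrogen. For the measured compounds named here, compounds 2 and 3 each carry a longer chain than compound 1 and sit higher in this assay, and that is the only guide. A rise beyond the scatter is expected, estimated as a number 1.00 log units higher from compound 1 to compound 4 (beyond the scatter). Compound 4 is accordingly expected to give 3.55, within 3.2 to 3.9.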

Compound 4, partition coefficient: 3.09
For compound 4 the middle estimate is 0.46 log units above the measured one; measured number outside the range, below it.
By their numbers in this assay, from the lowest: compound 1; then compound 4; then compound 3; then compound 2.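

With ethyl in place of hydrogen on a saturated chain carbon, eight bonds along the chain from an amine nitrogen, the series gains its first single-place comparison in this assay and the step reads a number 0.54 log units higher from compound 1 to compound 4 (beyond the scatter) as a modest change. The earlier compounds shown here differed in more than one place, so they could not isolate this change at this position. From the compounds shown here alone, whether a longer chain, an amine or a carboxylic acid at the same carbon would move the number differently remains open. Nothing shown here accounts for the size of this step.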